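The source may report more compounds than this note shows. Statements on the series, on what has been measured and on what is new or still open speak of the compounds shown alone.

Compound 1 `O=C1O/C(=C\Cn2cc(C(F)(F)F)c(=O)[nH]c2=O)C(OCc2ccccc2)=C1OCc1ccccc1`: 20000 nM
Compound 2 `O=C1O/C(=C\Cn2ccc(=O)[nH]c2=O)C(OCc2ccccc2)=C1OCc1ccccc1`: 50000 nM

Both compounds were tested in a functional assay on HeLa cells (Homo sapiens) for inhibition; on this read-out higher numbers stand for weaker inhibition and lower numbers for stronger inhibition. Of these two, compound 2 stands highest at 50000 nM, so it is the weaker inhibitor of the pair. The next compound to be tested is compound 3 `O=C1O/C(=C\Cn2cc(Cl)c(=O)[nH]c2=O)C(OCc2ccccc2)=C1OCc1ccccc1`. It differs from compound 2 by a single swap, chloro in place of hydrogen on an aromatic carbon.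

For the measured compounds named here, only one measured step bears on this swap: a 2.5-fold higher number from compound 1 to compound 2 (0.40 log units; beyond the scatter). That step was modest, and it involves the same place on the shared core, where compound 1 carries trifluoromethyl and compound 2 carries hydrogen. Read in reverse, it suggests that a group other than hydrogen at this place may lower the number. Chloro is a different group from trifluoromethyl, and one step is thin evidence, so only a small move in that direction is expected, no larger than the one already seen. The expected change is a 1.7-fold lower number from compound 2 to compound 3 (0.22 log units; within the scatter). The estimate for compound 3 is 30000 nM, with an expected range of 13000 nM to 65000 nM.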

Compound 3, half-maximal inhibitory concentration: 40000 nM
For compound 3 the middle estimate is 1.3-fold (0.12 log units) below the measured one, and the stated range covers the measured number.
By their numbers in this assay, from the lowest: compounds 1, 3 and 2 (each within the scatter of the next, the first and the last beyond it).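

In this assay, chloro on this aromatic carbon gives a 1.3-fold lower number from compound 2 to compound 3 (0.10 log units; within the scatter), so this swap cannot be told apart from no change at all. Chloro also cannot be separated from trifluoromethyl, since replacing one with the other gives a 2.0-fold higher number from compound 1 to compound 3 (0.30 log units; within the scatter), which means that compound 3 sits within the scatter of both earlier compounds even though those two lie beyond the scatter of each other. The third compound therefore adds no clear second step at this place, leaving the swap between trifluoromethyl and hydrogen as the only difference here that exceeds the scatter, and nothing available explains these numbers.

The compounds shown leave open whether a different group on this same aromatic carbon, such as a methyl, an amine or a nitrile, would give a number clearly apart from those of compound 1 and compound 2. They also leave open whether any group at this place could move the number far lower than that of compound 1, which stands at 20000 nM, rather than only within the narrow span seen so far.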